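Adding a methyl group to compound 1

A few compounds are considered here, and "the series" means these few. Any claim that something is new, unique, unknown or untested is made for them only; others in the source may bear on it.

Among the measured compounds shown here, in an ADME assay on HepG2 cells (Homo sapiens) for cytotoxicity, read by trypan blue exclusion, with a stated time of 48 h, in the presence of a further agent that is not named here (a lower number here means that less compound is tolerated, a higher number that more compound is tolerated), compound 1 `COc1ccc2nc(C)cc(OCC(=O)Nc3ccccc3)c2c1` gives 118000 nM as its half-maximal cytotoxic concentration, and this is the only exact number available so far. For the measured compounds named here, the one other measured compound is compound 2 `COc1cc(NC(=O)COc2cc(C)nc3ccc(OC)cc23)cc(OC)c1` with the same shared core. For compound 2 the reading > 131000 nM is a limit of the assay and not a number. Going by the values given here, the two readings therefore give no measured step and no firm order.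

Compound 3 `COc1ccc2nc(C)cc(OCC(=O)Nc3ccc(C)cc3)c2c1` differs from compound 1 in one place. The change is methyl in place of hydrogen on an aromatic carbon with methyl in place of hydrogen on an aromatic carbon, which turns phenyl to 4-methylphenyl. Among the compounds with values here, with no measured step to guide it, the expectation in this assay is for no shift beyond the usual scatter and for no particular direction, and it rests on compound 1 at 118000 nM as the only numerical anchor. The expected step of a 1.1-fold lower number from compound 1 to compound 3 (0.03 log units; within the scatter) is accordingly small. In this assay the estimated value for compound 3 is 110000 nM with an expected range from 55000 nM to 200000 nM as its lower and upper ends.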

Compound 3, half-maximal cytotoxic concentration: 41500 nM
Estimate against measurement, compound 3: 2.7-fold (0.42 log units) above, and the stated range ends above it.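

Methyl in place of hydrogen, which turns phenyl to 4-methylphenyl, gives a 2.8-fold lower number from compound 1 to compound 3 (0.45 log units; beyond the scatter) in this assay, and this is the first measured step in the series. It shows that this position, on an aromatic carbon of a six-membered aromatic ring of carbon only and para to a large group, is not indifferent to substitution: a single added carbon is enough for less compound to be tolerated. Compound 2 could not show this, as its reading is a limit and not a number: the limit of > 131000 nM in this assay, at which 1 of the 3 values shown sits.

From the compounds shown here alone, with a single step at a single position, it remains open whether the lower number is specific to methyl or would also follow from another group in the same place, such as a fluorine atom, a hydroxyl group or a longer chain like ethyl. Going by these compounds, it also remains open whether methyl on a different carbon of that ring would give a step of similar size, or any step beyond the scatter at all.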